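Ethylpiperazinyl for Dimethylamino: Caco-2 Permeability Outlook

The compounds below may be only part of what the source reports. "The series", "measured", "known", "first", "only" and "open" are said of these compounds alone.

Compound 1 `CNC(=O)c1cc(Oc2ccc3oc(Nc4ccc(Br)cc4)nc3c2)ccn1`: 10 10^-6 cm/s
Compound 2 `CCc1ccc(Nc2nc3cc(Oc4ccnc(C(=O)NC)c4)ccc3o2)cc1`: 10 10^-6 cm/s
Compound 3 `CNC(=O)c1cc(Oc2ccc3oc(Nc4ccc(N(C)C)cc4)nc3c2)ccn1`: 10 10^-6 cm/s

In an ADME assay on Caco-2 cells (Homo sapiens) for permeability, in the apical to basolateral direction (on this read-out higher numbers stand for higher permeability and lower numbers for lower permeability), compound 3 stands level with compounds 1 and 2 at the digits shown. The three measured steps, no change at the digits printed from compound 1 to compound 2 (within the scatter), no change at the digits printed from compound 1 to compound 3 (within the scatter) and no change at the digits printed from compound 2 to compound 3 (within the scatter), all stayed within the scatter. Compound 4 `CCN1CCN(c2ccc(Nc3nc4cc(Oc5ccnc(C(=O)NC)c5)ccc4o3)cc2)CC1` differs from compound 3 by 4-ethylpiperazin-1-yl in place of dimethylamino on an aromatic carbon. The measured steps exchanged one small group for another on that aromatic carbon; none of them brought in a ring there, so they bear on this change only loosely, and they give no sign of a shift beyond the scatter. Compound 4 is therefore expected to give 8 10^-6 cm/s in this assay, with a range from 3 10^-6 cm/s to 20 10^-6 cm/s. The step of a 1.3-fold lower number from compound 3 to compound 4 (0.10 log units; within the scatter) is expected to stay within the scatter.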

Compound 4, apparent permeability: 10 10^-6 cm/s
Compound 4: middle estimate off by 1.3-fold (0.10 log units), on the low side, and the stated range covers the measured number.
By their numbers in this assay, from the lowest: compounds 1, 2, 3 and 4 (each within the scatter of the next).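

Among the compounds shown, only compound 4 carries a ring on this aromatic carbon, para to a large group, and in this assay replacing dimethylamino with 4-ethylpiperazin-1-yl gives no change at the digits printed from compound 3 to compound 4 (within the scatter). The comparisons with ethyl and bromo at this position give no change at the digits printed from compound 2 to compound 4 (within the scatter) and no change at the digits printed from compound 1 to compound 4 (within the scatter), so the read-out stays within the scatter across all four groups, the six-membered non-aromatic ring included. No evidence is available to explain this result.

From the compounds shown here alone, whether a carboxylic acid, or a primary amine on a longer chain, would stay level at this position remains open. So does the outcome of changes elsewhere on the shared core.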